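The source may report more compounds than this note shows. Statements on the series, on what has been measured and on what is new or still open speak of the compounds shown alone.

Measured compounds in an ADME assay on MT4 cells (Homo sapiens) for cytotoxicity, read by MTT assay, with a stated time of 5 days; on this read-out lower numbers stand for higher toxicity in this test and higher numbers for lower toxicity in this test:
compound 1, `Cc1cc(/C=C/C#N)cc(C)c1Oc1nc(Nc2ccc(CN3CCN(S(C)(=O)=O)CC3)cc2)nc2sccc12`: 131000 nM
compound 2, `Cc1cc(/C=C/C#N)cc(C)c1Oc1nc(Nc2ccc(N3CCCC(NS(N)(=O)=O)C3)cc2)nc2sccc12`: > 217000 nM, a limit of the assay
compound 3, `Cc1cc(/C=C/C#N)cc(C)c1Oc1nc(Nc2ccc(N3CCN(S(N)(=O)=O)CC3)cc2)nc2sccc12`: > 222000 nM, a limit of the assay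

Compound 3 stands at the limit of this assay, with no number of its own; compound 2 likewise gives only a limit. Compound 1 gives a number, and the steps of an at least 1.6-fold higher number from compound 1 to compound 2 (0.21 log units; that floor lies within the scatter) and an at least 1.6-fold higher number from compound 1 to compound 3 (0.22 log units; that floor lies within the scatter) both have floors within the scatter, while a step that the two limits leave unreadable from compound 2 to compound 3 cannot be read. Compound 4, `Cc1cc(/C=C/C#N)cc(C)c1Oc1nc(Nc2ccc(CN3CCN(S(N)(=O)=O)CC3)cc2)nc2sccc12`, differs from compound 3 by (4-sulfamoylpiperazin-1-yl)methyl in place of 4-sulfamoylpiperazin-1-yl on an aromatic carbon. Compound 1 already carries a methylene linker of this kind and sits close to the limits of compound 2 and compound 3, so no step beyond the scatter is expected here. Compound 4 is therefore estimated at 200000 nM, in a range from 100000 nM to 300000 nM, meaning an expected step of an at least 1.1-fold lower number from compound 3 to compound 4 (0.04 log units; that floor lies within the scatter).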

Compound 4, half-maximal cytotoxic concentration: > 217000 nM
Compound 4 ended at the assay's limit (the forecaster's own chance of this, stated with the estimate: 50%); at least 1.0-fold (0.03 log units) between middle value and limit.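

In this assay, (4-sulfamoylpiperazin-1-yl)methyl on this aromatic carbon, para to a large group, leaves compound 4 at a limit of the assay, as 4-sulfamoylpiperazin-1-yl does for compound 3, and the steps from compound 2 and compound 3 to compound 4 cannot be read. Amino in place of methyl on the sulfonyl sulfur gives an at least 1.6-fold higher number from compound 1 to compound 4 (0.21 log units; that floor lies within the scatter). Compound 4 shares its limit with compound 2: the limit of > 217000 nM in this assay, at which 2 of the 4 values shown sit.

Going by these compounds, how far compound 2, compound 3 and compound 4 lie past their limits stays open. So does whether a carboxylic acid or a longer chain at this aromatic carbon would give a measured number.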